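The source may report more compounds than this note shows. Statements on the series, on what has been measured and on what is new or still open speak of the compounds shown alone.

Series notes. Three analogues have been run in a functional assay on MCF7 cells (Homo sapiens) for cytotoxicity, read by sulforhodamine B assay, with a stated time of 48 h; on this read-out lower numbers stand for higher toxicity in this test and higher numbers for lower toxicity in this test. Compound 1 `COc1ccc2[nH]cc(C(=O)/C(C#N)=C/C=C(\Cl)c3ccc(Br)cc3)c2c1` gives > 100000 nM, which is a limit of the assay rather than a number. Compound 2 `COc1cc(/C(Cl)=C/C=C(\C#N)C(=O)c2c[nH]c3ccc(Br)cc23)cc(OC)c1OC` likewise returns only a limit, > 100000 nM. Compound 3 `N#C/C(=C\C=C(/Cl)c1ccc(Br)cc1)C(=O)c1c[nH]c2ccc(Br)cc12` also stops at a limit, > 100000 nM. All three therefore share one reading, (the limit of > 100000 nM in this assay, at which 3 of the 3 values shown sit), and nothing in this assay separates them.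

Within the data shown here, the only single-point change measured runs from compound 3 to compound 1: methoxy in place of bromo on an aromatic carbon. Its size is a step that the two limits leave unreadable from compound 3 to compound 1, both ends being limits. Compound 2 and compound 3 differ in more than one place; the difference between the two cores is not broken down here.

Compound 4 `COc1ccc2[nH]cc(C(=O)/C(C#N)=C/C=C(\Cl)c3cc(OC)c(OC)c(OC)c3)c2c1` stands to compound 2 as compound 1 stands to compound 3: methoxy in place of bromo on an aromatic carbon. The two place descriptions match word for word, so this is the same change, made twice within the set. Because a step that the two limits leave unreadable from compound 3 to compound 1 gave no readable size, the step from compound 2 to compound 4 is expected to behave the same way, with a further limit the most likely outcome; the expected step is a step that the limit leaves unreadable from compound 2 to compound 4. For compound 4 in this assay the estimate is 150000 nM, expected to fall between 50000 nM and 500000 nM.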

Compound 4, concentration lethal to 50% of the cells: > 100000 nM
Compound 4 ended at the assay's limit; the forecaster's own chance of this, stated with the estimate: 85%; the middle value lies beyond the limit too.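

No step can be read from compound 2 to compound 4, as both ends are limits, and the series stays at a single reading: the limit of > 100000 nM in this assay, at which 4 of the 4 values shown sit.

The compounds shown leave open whether methoxy in place of bromo on an aromatic carbon alters the result in this assay at all, and what structure would give a readable value.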